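This account rests on a few compounds, and the source may have more. Where it says the series, first, only, none or still open, it means among the compounds named here.

Series of sulfonamides sharing the core of compound 1 `COc1ccc(CNCCCNS(=O)(=O)c2cc(C(F)(F)F)cc(C(F)(F)F)c2)cc1OC`, varied only in the aryl group on a saturated chain carbon bound to an amine nitrogen. In a functional assay on BXPC-3 cells (Homo sapiens) for inhibition, read by MTT assay, with a stated time of 72 h (on this read-out higher numbers stand for weaker inhibition of growth and lower numbers for stronger inhibition of growth), compound 1 gives 13000 nM. Compound 2 `O=S(=O)(NCCCNCc1ccc(C(F)(F)F)cc1)c1cc(C(F)(F)F)cc(C(F)(F)F)c1` gives 1700 nM in this assay, and compound 3 `O=S(=O)(NCCCNCc1ccc(Cl)c(C(F)(F)F)c1)c1cc(C(F)(F)F)cc(C(F)(F)F)c1` gives 7800 nM. Compound 3 thus stands second highest of the three numbers, separated from compound 1 by a 1.7-fold lower number from compound 1 to compound 3 (0.22 log units; within the scatter) and from compound 2 by a 4.6-fold higher number from compound 2 to compound 3 (0.66 log units; beyond the scatter); compound 2 stands apart from compound 1 by a 7.6-fold lower number from compound 1 to compound 2 (0.88 log units; beyond the scatter).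

Compound 4 `COc1ccc(CNCCCNS(=O)(=O)c2cc(C(F)(F)F)cc(C(F)(F)F)c2)cc1` differs from compound 3 by 4-methoxyphenyl in place of 4-chloro-3-(trifluoromethyl)phenyl on a saturated chain carbon bound to an amine nitrogen. Among the measured compounds shown here, the only measured step bearing on it is a 1.7-fold lower number from compound 1 to compound 3 (0.22 log units; within the scatter), which exchanges a dimethoxyphenyl for the same chloro-trifluoromethyl group and stays within the scatter. A 4-methoxyphenyl is the closer relative of the 3,4-dimethoxyphenyl of compound 1, so no step beyond the scatter is expected in this assay, in either direction. Compound 4 is therefore estimated at 10000 nM, with a range from 4000 nM to 30000 nM. The step expected from compound 3 to compound 4 is a 1.3-fold higher number from compound 3 to compound 4 (0.11 log units; within the scatter).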

Compound 4, concentration for 50% growth inhibition: 1300 nM
Compound 4: the middle estimate sits 7.7-fold (0.89 log units) above what was measured; measured number outside the range, below it.
By their numbers in this assay, from the lowest: compounds 4 and 2 (each within the scatter of the next); then compounds 3 and 1 (each within the scatter of the next).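

In this assay, the step of a 10-fold lower number from compound 1 to compound 4 (1.00 log units; beyond the scatter) shows that this aryl position responds strongly to a single change: removing one methoxy group from the 3,4-dimethoxyphenyl. The 4-methoxyphenyl and 4-(trifluoromethyl)phenyl groups cannot be told apart, with a 1.3-fold lower number from compound 2 to compound 4 (0.12 log units; within the scatter), so the earlier contrast between compound 1 and compound 2 does not follow from methoxy versus trifluoromethyl as such. Across these four compounds, the aryl groups with one substituent give lower numbers than those with two, as a 6.0-fold lower number from compound 3 to compound 4 (0.78 log units; beyond the scatter) also shows, with no compound against this pattern, and no measurement at hand accounts for it.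

Still open, on these data alone, is whether this pattern depends on the number of substituents or on the particular groups involved. Unsubstituted phenyl, 3-methoxyphenyl, 4-chlorophenyl and 3-(trifluoromethyl)phenyl would help separate these readings.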